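The source may report more compounds than this note shows. Statements on the series, on what has been measured and on what is new or still open speak of the compounds shown alone.

Compound 3, with the structure `COc1cc(NC(C)CCCNC(=O)NNC(=O)NCCCCCO)c2ncccc2c1`, gives 54% in a physicochemical assay for inhibition, read by spectrophotometry, tested at 100 uM; a lower number here means less inhibition, a higher number more inhibition at the concentration tested (going by the name of the read-out). That number is the lowest of the three measured, though neither gap reaches beyond the usual scatter. Compound 1, `COc1cc(NC(C)CCCNC(=O)Nc2ccc(Cl)c(C(F)(F)F)c2)c2ncccc2c1`, gives 61% in this assay, and compound 2, `COc1cc(NC(C)CCCNC(=O)NNC(=O)Nc2ccc(Cl)c(C(F)(F)F)c2)c2ncccc2c1`, gives 63%. The step of a number 7 percentage points lower from compound 1 to compound 3 (within the scatter) and the step of a number 9 percentage points lower from compound 2 to compound 3 (within the scatter) both stay within the scatter, so exchanging the 4-chloro-3-(trifluoromethyl)phenyl group for a 5-hydroxypentyl chain on the amide-type nitrogen has left the read-out where it was.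

Compound 4, `COc1cc(NC(C)CCCNC(=O)NNC(=O)NCCCO)c2ncccc2c1`, is not yet measured. It differs from compound 3 by hydroxy in place of 2-hydroxyethyl on a saturated chain carbon, three bonds along the chain from an amide-type nitrogen. The two measured steps concern the replacement of the aryl group by the hydroxyalkyl chain, not the length of that chain, so they bear on this step only loosely: they show that a change in this part of the molecule has so far left the number in this assay level. Going by the values given here, no measured pair tests a shortening of the chain, so nothing beyond the scatter is expected in either direction. The expected step of a number 2 percentage points lower from compound 3 to compound 4 (within the scatter) is therefore small. Compound 4 is estimated to give 52% in this assay, expected to fall between 38% and 66%.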

Compound 4, a percentage reported as inhibition, at one concentration (the size of the read-out at that concentration, not a potency): 45%
Estimate against measurement, compound 4: 7 percentage points above, within the range that was stated.
By their numbers in this assay, from the lowest: compounds 4, 3, 1 and 2 (each within the scatter of the next, the first and the last beyond it).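

Going by these compounds alone, until this result, exchanging the 4-chloro-3-(trifluoromethyl)phenyl group for a hydroxyalkyl chain had stayed within the scatter, but with 3-hydroxypropyl as the chain the exchange gives a separation that can be read in this assay: a number 18 percentage points lower from compound 2 to compound 4 (beyond the scatter) and a number 16 percentage points lower from compound 1 to compound 4 (beyond the scatter), both of them modest. Within the data shown here, this is also the first measured change of chain length, hydroxy in place of 2-hydroxyethyl on a saturated chain carbon, three bonds along the chain from an amide-type nitrogen, and the direct step of a number 9 percentage points lower from compound 3 to compound 4 (within the scatter) does not on its own separate the two chains. The 3-hydroxypropyl and 5-hydroxypentyl chains therefore differ only in how each stands against compound 1 and compound 2, not in any difference shown directly between compound 3 and compound 4.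

The compounds shown leave open where 4-hydroxybutyl or a longer chain would fall in this assay, and whether a plain propyl chain, or an amine or a carboxylic acid in place of the hydroxy, would read differently. Nothing given here accounts for these differences.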